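Tetrazolyl quinolinone series: bromo replacing isopropyl

The compounds below may be only part of what the source reports. "The series", "measured", "known", "first", "only" and "open" are said of these compounds alone.

The three measured compounds share one core and differ only at one aromatic carbon. Compound 1 `O=c1c(-c2nn[nH]n2)c[nH]c2c(Cl)cccc12` carries chloro there and in a functional assay on the whole organism (strain Sprague-Dawley) for inhibition, with Rattus norvegicus as the target (a higher number here means that more compound is needed for the effect, a lower number that less compound is needed), gives 0.078 mg/kg. Compound 2 `CCc1cccc2c(=O)c(-c3nn[nH]n3)c[nH]c12` carries ethyl and gives 0.312 mg/kg, and compound 3 `CC(C)c1cccc2c(=O)c(-c3nn[nH]n3)c[nH]c12` carries isopropyl and gives 1.25 mg/kg. Compound 3 therefore stands at the highest number of the three: the step of a 4.0-fold higher number from compound 2 to compound 3 (0.60 log units; beyond the scatter) and the step of a 16-fold higher number from compound 1 to compound 3 (1.20 log units; beyond the scatter) both run upward, beyond the scatter, as does a 4.0-fold higher number from compound 1 to compound 2 (0.60 log units; beyond the scatter).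

Compound 4 `O=c1c(-c2nn[nH]n2)c[nH]c2c(Br)cccc12` is not yet measured. It differs from compound 3 as follows: bromo in place of isopropyl on an aromatic carbon. The step that bears on it most directly is a 16-fold higher number from compound 1 to compound 3 (1.20 log units; beyond the scatter), which runs in the opposite direction: replacing chloro by isopropyl raised the number by a large amount. Bromo, like chloro, enters as a single heavy atom at the same aromatic carbon, so compound 4 is expected to return toward the number of compound 1 rather than stay near compound 3. Accordingly the step of a 13-fold lower number from compound 3 to compound 4 (1.10 log units; beyond the scatter) is expected to be downward and large, because of the size of a 16-fold higher number from compound 1 to compound 3 (1.20 log units; beyond the scatter). For compound 4 the estimate in this assay is 0.1 mg/kg, with a range from 0.04 mg/kg to 0.3 mg/kg.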

Compound 4, minimum effective dose: > 5 mg/kg
Compound 4 was reported as a limit (the forecaster's own chance of this, stated with the estimate: 5%); middle value at least 50-fold (1.69 log units) from the limit.
By their numbers in this assay, from the lowest: compound 1; then compound 2; then compound 3. At a limit, above all of these: compound 4.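

In this assay compound 4 is reported only as a limit, not as a number: the limit of > 5 mg/kg in this assay, at which 1 of the 4 values shown sits.

At this aromatic carbon the change from one halogen to another is far from neutral, as bromo in place of chloro gives an at least 64-fold higher number from compound 1 to compound 4 (1.80 log units; beyond the scatter), so a single heavy atom here does not by itself keep the low number of compound 1. Bromo also ends up past both alkyl groups, with an at least 16-fold higher number from compound 2 to compound 4 (1.20 log units; beyond the scatter) and an at least 4.0-fold higher number from compound 3 to compound 4 (0.60 log units; beyond the scatter), so the rise from chloro through ethyl to isopropyl does not follow heavy-atom count across the series, and compound 4 goes against that reading since bromo enters with fewer heavy atoms than the isopropyl that leaves.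

From the compounds shown here alone, all three steps are lower bounds, and how far compound 4 lies past its limit stays open. Also open, going by these compounds, is whether chloro is a narrow optimum at this carbon or whether fluoro, methoxy or trifluoromethyl there would hold a number near that of compound 1.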